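The source may report more compounds than this note shows. Statements on the series, on what has been measured and on what is new or still open speak of the compounds shown alone.

In a functional assay on FM3A cells (Mus musculus) for antiproliferative activity, read by cell counting, with a stated time of 2 days (a higher number here means a weaker inhibitor, a lower number a stronger inhibitor), compound 1 `COc1ccc(Nc2nc(N)c(C(=O)c3ccccc3)s2)cc1` gives 730 nM. Compound 3 `COc1ccccc1C(=O)c1sc(Nc2ccccc2)nc1N` gives 1100 nM, which lies within the usual scatter of the value for compound 1, so these two numbers cannot be ranked. Together they form the lower part of the small set of numbers available. Compound 2 `Nc1nc(Nc2ccc(Cl)cc2)sc1C(=O)c1ccccc1` gives only a limit of the assay, > 10000 nM.

Compound 4 `COc1ccc(Nc2nc(N)c(C(=O)c3ccc([N+](=O)[O-])cc3)s2)cc1` keeps the methoxy of compound 1 and adds one group: nitro in place of hydrogen on an aromatic carbon. This is nitro in place of hydrogen on an aromatic carbon of a six-membered aromatic ring of carbon only, para to a large group.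

For the measured compounds named here, only one measured step can guide an expectation: an at least 13-fold higher number from compound 1 to compound 2 (1.13 log units; beyond the scatter). That change lies at the methoxy and not at the place where the nitro enters, so it bears on compound 4 only indirectly. Going by the values given here, it does show that a single exchange on an aromatic carbon can cost a great deal in these compounds, and no measured step shows a gain over compound 1. A moderate move toward a weaker inhibitor therefore seems likely, with wide uncertainty.

The estimate amounts to an expected 2.1-fold higher number from compound 1 to compound 4 (0.31 log units; beyond the scatter). For compound 4, the expected value in this assay is 1500 nM, with an estimated range from 300 nM to 8000 nM.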

Compound 4, half-maximal inhibitory concentration: 310 nM
Estimate against measurement, compound 4: 4.8-fold (0.68 log units) above, within the range that was stated.
By their numbers in this assay, from the lowest: compound 4; then compounds 1 and 3 (each within the scatter of the next). At a limit, above all of these: compound 2.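

Nitro in place of hydrogen on an aromatic carbon, para to a large group, gives a 2.4-fold lower number from compound 1 to compound 4 (0.37 log units; beyond the scatter) in this assay and is the first measured step in this set that leads to a stronger inhibitor rather than a weaker one. For the compounds shown here, the only earlier step between compounds differing in one place was at the methoxy, so it said nothing directly about this carbon, whereas compound 4 shows that this carbon accepts a nitro group with no loss and with a modest gain. The compounds shown give no measurement that explains why the number fell with this change.

From the compounds shown here alone, it remains open whether the gain belongs to nitro itself, or whether an amine or a carboxylic acid on this same carbon would move the number in the same direction and by a similar amount. Going by these compounds, it is also open whether nitro at this carbon would give a similar step when chloro replaces the methoxy, as in compound 2, whose > 10000 nM is a limit of the assay.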